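Ester variation at the shared core

The source may hold more compounds than are shown below. What is called first, only, known or untested is meant among the compounds shown, and "the series" means these compounds.

Measured compounds:
compound 1 `Cc1ccc(C(=O)OC2(C(=O)Nc3ccc([N+](=O)[O-])cc3)CCCCC2)cc1`: 9.8 nM
compound 2 `O=C(OC1(C(=O)Nc2ccc([N+](=O)[O-])cc2)CCCCC1)c1ccccc1`: 903 nM
compound 3 `CC(=O)OC1(C(=O)Nc2ccc([N+](=O)[O-])cc2)CCCCC1`: 403 nM

In a functional assay on MCF7 cells (Homo sapiens) for inhibition, read by MTT assay, with a stated time of 72 h (on this read-out higher numbers stand for weaker inhibition and lower numbers for stronger inhibition), compound 1 holds the lowest number of the three; the nearest measured step away from it is a 41-fold higher number from compound 1 to compound 3 (1.61 log units; beyond the scatter) and the furthest is a 92-fold higher number from compound 1 to compound 2 (1.96 log units; beyond the scatter). Compound 4 `CCC(=O)OC1(C(=O)Nc2ccc([N+](=O)[O-])cc2)CCCCC1` is not yet measured. Its change from compound 1 is ethyl in place of 4-methylphenyl on a carbonyl carbon. The step that bears most directly on this is a 41-fold higher number from compound 1 to compound 3 (1.61 log units; beyond the scatter), where the same 4-methylphenyl gave way to methyl; the modest step of a 2.2-fold lower number from compound 2 to compound 3 (0.35 log units; beyond the scatter) set phenyl against methyl. Ethyl, like methyl, is a short chain with no ring, so by analogy with compound 3 a large rise in this assay is expected, a 36-fold higher number from compound 1 to compound 4 (1.55 log units; beyond the scatter). Compound 4 is accordingly estimated at 350 nM, within 100 nM to 1200 nM.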

Compound 4, half-maximal inhibitory concentration: 14.1 nM
Beside the measured number, compound 4's estimate is 25-fold (1.39 log units) above it; measured number below the stated range.
By their numbers in this assay, from the lowest: compounds 1 and 4 (each within the scatter of the next); then compound 3; then compound 2.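

Ethyl on this carbonyl carbon stands level with 4-methylphenyl (a 1.4-fold higher number from compound 1 to compound 4 (0.16 log units; within the scatter)), so in this assay a low number here does not depend on an aromatic ring. Small changes at this position can give large steps: methyl in place of hydrogen on the saturated chain carbon gives (a 29-fold lower number from compound 3 to compound 4 (1.46 log units; beyond the scatter)), and ethyl in place of phenyl gives (a 64-fold lower number from compound 2 to compound 4 (1.81 log units; beyond the scatter)). The number does not follow the size of the group, with compound 2 and compound 3 going against any such order.

Nothing shown accounts for these steps. From the compounds shown here alone, whether a longer chain such as butyl, or a chain ending in a carboxylic acid, keeps the low number remains open.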